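Replacing propyl with (pyridin-4-yl)methyl at the amide-type nitrogen

A few compounds are considered here, and "the series" means these few. Any claim that something is new, unique, unknown or untested is made for them only; others in the source may bear on it.

Two related compounds have been measured so far. In an ADME assay on SW1353 cells (Homo sapiens) for cytotoxicity, read by a luciferase reporter, with a stated time of 30 min (on this read-out higher numbers stand for lower toxicity in this test and lower numbers for higher toxicity in this test), compound 1 (`O=C(Nc1ccc(N2CCNCC2)cc1C(F)(F)F)c1ccc(-c2ccc(Cl)cc2)o1`) gives 18000 nM as its half-maximal cytotoxic concentration. In this assay compound 2 (`CCCN(C(=O)c1ccc(-c2ccc(Cl)cc2)o1)c1ccc(N2CCNCC2)cc1`) reads > 20000 nM, which is a limit of the assay and not a number. Compound 2 therefore has no exact position on this scale.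

The next compound to be tested is compound 3 (`O=C(c1ccc(-c2ccc(Cl)cc2)o1)N(Cc1ccncc1)c1ccc(N2CCNCC2)cc1`), which differs from compound 2 in one place: pyridin-4-yl in place of ethyl on a saturated chain carbon bound to an amide-type nitrogen. In words, pyridin-4-yl stands in place of ethyl on a saturated chain carbon bound to an amide-type nitrogen, so that propyl becomes (pyridin-4-yl)methyl. Going by the values given here, no measured pair shows what a change at this place does, so the expectation is a cautious one and stays close to the nearest neighbour. The expected a number no higher from compound 2 to compound 3 (the limit leaves the size open) in this assay is none beyond the scatter, with no firm direction. Compound 3 is estimated at 20000 nM, with an expected range from 9000 nM to 30000 nM, and it may well return only a limit.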

Compound 3, half-maximal cytotoxic concentration: > 8000 nM
Compound 3 ended at the assay's limit; the forecaster's own chance of this, stated with the estimate: 60%; the middle value lies beyond the limit too.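

In this assay compound 2 reads > 20000 nM, which is a limit of the assay and not a number. Going by these compounds alone, compound 3 reads > 8000 nM, also a limit and not a number, so no step between compound 2 and compound 3 can be read. The compounds shown leave open what replacing propyl with (pyridin-4-yl)methyl does to this read-out.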